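This account rests on a few compounds, and the source may have more. Where it says the series, first, only, none or still open, it means among the compounds named here.

Working notes on the series, read in a physicochemical assay for solubility; a lower number here means a less soluble compound, a higher number a more soluble compound. Compound 1 (`O=C(O)c1ccc(C(=O)/C(=C\c2ccc(O)c([N+](=O)[O-])c2)SCc2ccc(Br)cc2)cc1`) gives < 1000 ug/mL, which is a limit and not a number. Compound 2 (`O=C(O)c1ccc(C(=O)/C(=C\c2ccc(Br)c([N+](=O)[O-])c2)SCc2ccc(Cl)cc2)cc1`) gives < 1000 ug/mL, also a limit. Compound 3 (`O=C(O)c1ccc(C(=O)/C(=C\c2ccc(F)c([N+](=O)[O-])c2)SCc2ccc(C(F)(F)F)cc2)cc1`) gives < 1000 ug/mL, again a limit. Within the data shown here, compound 1 therefore has no exact place: the measured set amounts to the limit of < 1000 ug/mL in this assay, at which 3 of the 3 values shown sit, and no step between measured compounds can be sized.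

Compound 4 (`O=C(O)c1ccc(C(=O)/C(=C\c2ccc(Cl)c([N+](=O)[O-])c2)SCc2ccc(Br)cc2)cc1`) has not yet been measured in this assay. It keeps the core of compound 1 and differs in one place: chloro in place of hydroxy on an aromatic carbon. In words, this is chloro in place of hydroxy on an aromatic carbon, so 4-hydroxy-3-nitrophenyl becomes 4-chloro-3-nitrophenyl. Among the measured compounds shown here, no measured step covers this change, so the data give no direction for it, and no step beyond the scatter is expected. The estimated change is a step that the limit leaves unreadable from compound 1 to compound 4, an expected figure set against a limit rather than against a number. The expectation rests on compound 1 with its limit of < 1000 ug/mL. The most likely outcome is another reading that gives only a limit. For compound 4 the estimated value is 300 ug/mL, with an expected range of 50 ug/mL to 1000 ug/mL.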

Compound 4, solubility: < 1000 ug/mL
Compound 4 gave a limit, no number; the forecaster's own chance of this, stated with the estimate: 90%; the middle value lies beyond the limit too.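

Compound 1 and compound 4 each give only a limit in this assay, not a number, so no step can be read for chloro in place of hydroxy on an aromatic carbon: the limit of < 1000 ug/mL in this assay, at which 4 of the 4 values shown sit.

The compounds shown leave open where any of them lies as an exact value, and whether this change shifts the read-out at all.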